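Dropping one methoxy group from a dimethoxyphenyl side ring

The source may hold more compounds than are shown below. What is called first, only, known or untested is meant among the compounds shown, and "the series" means these compounds.

Compound 2 `COc1cc(OC)cc(-c2nc(O)c3c(n2)c(C)nn3C)c1` carries two methoxy groups on its aromatic side ring. In an assay on membranes from brain for binding affinity to adenosine receptor A1 (Rattus norvegicus), read by radioligand binding (a higher number here means a weaker inhibitor, a lower number a stronger inhibitor), compound 2 gives 7060 nM, the highest number of the two measured here, whereas compound 1 `Cc1nn(C)c2c(O)nc(-c3cccc([N+](=O)[O-])c3)nc12` gives 1200 nM, a lower number that lies beyond the usual scatter. Compound 3 `COc1cccc(-c2nc(O)c3c(n2)c(C)nn3C)c1` differs from compound 2 by hydrogen in place of methoxy on an aromatic carbon, a hydrogen in place of methoxy on an aromatic carbon. Going by the values given here, no measured pair shows this change on its own. A moderately lower number is expected, so compound 3 is estimated at 3500 nM in this assay, with a range from 1500 nM to 8000 nM, an expected step of a 2.0-fold lower number from compound 2 to compound 3 (0.30 log units; within the scatter).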

Compound 3, half-maximal inhibitory concentration: 1470 nM
Compound 3: middle estimate off by 2.4-fold (0.38 log units), on the high side; the whole stated range lies above it.
By their numbers in this assay, from the lowest: compounds 1 and 3 (each within the scatter of the next); then compound 2.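

Removing the second methoxy group gives a 4.8-fold lower number from compound 2 to compound 3 (0.68 log units; beyond the scatter) in this assay, so the presence of this group on the side ring makes a real difference to the number. Once only one methoxy group remains, methoxy in place of nitro on an aromatic carbon gives a 1.2-fold higher number from compound 1 to compound 3 (0.09 log units; within the scatter), and the two groups cannot be told apart. No available measurement explains either step.

Going by these compounds, it remains open how an amine or a carboxylic acid at this place on the ring would compare. Also open, on these data alone, is what hydrogen in place of the remaining methoxy group would do.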